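Trifluoromethyl in Place of Methyl: A Flat Readout Expected

The source may hold more compounds than are shown below. What is called first, only, known or untested is meant among the compounds shown, and "the series" means these compounds.

Three related compounds have been tested in a functional assay on Hep 3B2 cells (Homo sapiens) for antiproliferative activity, read by MTT assay, with a stated time of 24 h, tested at 0.05 ug/mL; a higher number here means a stronger effect of the compound at the concentration tested, a lower number a weaker effect. Compound 1 `Cc1ccc2nc(C(=O)Nc3c(F)cc(-c4cccc(F)c4)cc3F)c(C)c(O)c2c1` gives 1.52%, compound 2 `Cc1c(C(=O)Nc2c(F)cc(-c3cccc(F)c3)cc2F)nc2ccc(F)cc2c1O` gives 1.25%, and compound 3 `CCOc1ccc2nc(C(=O)Nc3c(F)cc(-c4cccc(F)c4)cc3F)c(C)c(O)c2c1` gives -0.04%. Compound 1 holds the highest of the three numbers, yet its margin over the others is slight: a number 0.3 percentage points lower from compound 1 to compound 2 (within the scatter) and a number 1.6 percentage points lower from compound 1 to compound 3 (within the scatter), both within the scatter, so the three compounds cannot be told apart on this readout. The comparison of compound 2 with compound 3 is likewise flat, a number 1.3 percentage points lower from compound 2 to compound 3 (within the scatter).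

Compound 4 `Cc1c(C(=O)Nc2c(F)cc(-c3cccc(F)c3)cc2F)nc2ccc(C(F)(F)F)cc2c1O` is the compound still to be measured. Relative to compound 1 the change is trifluoromethyl in place of methyl on an aromatic carbon. The measured steps that bear on this are the two that exchange the same methyl for another group, fluoro in compound 2 and ethoxy in compound 3, and neither of those moved the readout beyond the scatter. On that basis no step beyond the scatter is expected in this assay for this third exchange at the same aromatic carbon. The expected step is a number 0.5 percentage points lower from compound 1 to compound 4 (within the scatter), within the scatter. Compound 4 is therefore estimated at 1%, with a range from -8% to 10%.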

Compound 4, a percentage reported as inhibition, at one concentration (the size of the read-out at that concentration, not a potency): 1.35%
Compound 4: middle estimate off by 0.4 percentage points, on the low side, within the range that was stated.
By their numbers in this assay, from the lowest: compounds 3, 2, 4 and 1 (each within the scatter of the next).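

Trifluoromethyl brings four heavy atoms where methyl has one, yet in this assay this exchange on the aromatic carbon gives a number 0.2 percentage points lower from compound 1 to compound 4 (within the scatter) and so leaves the readout as flat as the smaller fluoro exchange did. The new group also matches the other two replacements, with a number 0.1 percentage points higher from compound 2 to compound 4 (within the scatter) and a number 1.4 percentage points higher from compound 3 to compound 4 (within the scatter) as its steps, which means that methyl, fluoro, ethoxy and trifluoromethyl at this one position cannot be told apart here, and all four numbers lie close to zero at the single concentration tested. Nothing measured on these compounds offers an explanation for this flatness.

With every number so near zero, the readout leaves little room to see any effect of this position, so the flat result may say more about the test conditions than about the groups themselves. Going by these compounds, it remains open whether a group of another kind on the same aromatic carbon, such as an amine, a carboxylic acid or a longer chain, would move the readout beyond the scatter.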